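Three Inactive Thiazoles and a Urea Analogue

The compounds below may be only part of what the source reports. "The series", "measured", "known", "first", "only" and "open" are said of these compounds alone.

Compound 1, `CCOc1ccc(-c2nc(NS(=O)(=O)c3ccc(OC)c(F)c3)sc2-c2cc(OC)c(OC)c(OC)c2)cc1`: in a functional assay on SK-OV-3 cells (Homo sapiens) for antiproliferative activity, read by MTT assay, with a stated time of 48 h (on this read-out lower numbers stand for stronger inhibition and higher numbers for weaker inhibition), compound 1 gives > 5000 nM, which is a limit of the assay and not a number.
Compound 2, `C=CCN(CC=C)c1nc(-c2ccc(OCC)cc2)c(-c2cc(OC)c(OC)c(OC)c2)s1`: in this assay compound 2 gives > 5000 nM, again a limit rather than a number.
Compound 3, `CCCN(CCC)c1nc(-c2ccc(OCC)cc2)c(-c2cc(OC)c(OC)c(OC)c2)s1`: in this assay compound 3 gives > 5000 nM, also a limit and not a number.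

Compound 2 therefore stands at a limit, like every other value shown; all three sit at the limit of > 5000 nM in this assay, at which 3 of the 3 values shown sit. Going by the values given here, the one step among measured compounds, a step that the two limits leave unreadable from compound 2 to compound 3, cannot be read for size, since both ends are limits.

Compound 4, `CCNC(=O)Nc1nc(-c2ccc(OCC)cc2)c(-c2cc(OC)c(OC)c(OC)c2)s1`, has not yet been measured. It differs from compound 2 by (ethylcarbamoyl)amino in place of diallylamino on an aromatic carbon. Among the compounds with values here, no measured step bears on this change: the step from diallylamino to dipropylamino gives no readable size, and the sulfonamide of compound 1 also sits at the limit. With nothing beyond limits to build on, compound 4 is expected to stay near the limit, so the step that the limit leaves unreadable from compound 2 to compound 4 is estimated as none beyond the scatter. Compound 4 is thus expected to give about 7000 nM in this assay, within 2000 nM to 25000 nM.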

Compound 4, half-maximal inhibitory concentration: 29.2 nM
The estimate for compound 4 lay 240-fold (2.38 log units) above the measured number; the whole stated range lies above it.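

In this assay the group on this aromatic carbon, two ring bonds from the 4-ethoxyphenyl group, turns out to decide the outcome: (ethylcarbamoyl)amino in place of diallylamino gives an at least 170-fold lower number from compound 2 to compound 4 (2.23 log units; beyond the scatter), the same group in place of dipropylamino gives an at least 170-fold lower number from compound 3 to compound 4 (2.23 log units; beyond the scatter), and ethylcarbamoyl in place of (3-fluoro-4-methoxyphenyl)sulfonyl on the nitrogen gives an at least 170-fold lower number from compound 1 to compound 4 (2.23 log units; beyond the scatter). The earlier compounds shown here could not show that this position can carry strong activity at all, and the count of 2 hydrogen-bond donors in (ethylcarbamoyl)amino against 0 in diallylamino is a difference in structure only, with nothing here tying it to the result. Each of these sizes is a minimum, since the far end of each step is a limit and not a number: the limit of > 5000 nM in this assay, at which 3 of the 4 values shown sit.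

As far as these compounds go, what remains open is which part of (ethylcarbamoyl)amino carries the effect, a question that a free amine, an acetylamino group or a longer chain in place of the ethyl would help to answer. From the compounds shown here alone, it is also open whether the same gain would appear with a group other than 4-ethoxyphenyl on the shared core.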